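Cyclopentyl to oxan-4-yl on the sulfonamide side chain

The source may report more compounds than this note shows. Statements on the series, on what has been measured and on what is new or still open speak of the compounds shown alone.

Measured so far:
compound 1 `CC1(C)CO[C@H]1CN([C@H](CCC(F)(F)F)C(N)=O)S(=O)(=O)c1ccc(Cl)cc1`, in a physicochemical assay for lipophilicity, read by HPLC, measured as octanol-water partition, at pH 7.4 (a lower number here means a more polar compound, a higher number a more lipophilic compound), compound 1 gives 3.8
compound 2 `NC(=O)[C@@H](CCC(F)(F)F)N(CC1CCCC1)S(=O)(=O)c1ccc(Cl)cc1`, in this assay compound 2 gives 5.15

Compound 2 stands highest of the two numbers in this assay; its nearest neighbour is compound 1, separated by a number 1.35 log units higher from compound 1 to compound 2 (beyond the scatter). Compound 3 `NC(=O)[C@@H](CCC(F)(F)F)N(CC1CCOCC1)S(=O)(=O)c1ccc(Cl)cc1` differs from compound 2 by oxan-4-yl in place of cyclopentyl on a saturated chain carbon bound to a sulfonamide nitrogen. Among the measured compounds shown here, the only measured step, a number 1.35 log units higher from compound 1 to compound 2 (beyond the scatter), bears on this change in reverse: there the cyclopentyl replaced a ring with a hetero atom and the number rose sharply. A drop of comparable size is therefore expected here, a number 1.15 log units lower from compound 2 to compound 3 (beyond the scatter). Compound 3 is estimated at 4, within 3.5 to 4.5.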

Compound 3, distribution coefficient: 3.5
Beside the measured number, compound 3's estimate is 0.50 log units above it; low and high end bracket the measured number.
By their numbers in this assay, from the lowest: compounds 3 and 1 (each within the scatter of the next); then compound 2.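

In this assay, oxan-4-yl in place of cyclopentyl gives a number 1.65 log units lower from compound 2 to compound 3 (beyond the scatter), so a second ring with a hetero atom, after 3,3-dimethyloxetan-2-yl, stands well apart from the carbon-only ring at this place on a saturated chain carbon bound to a sulfonamide nitrogen. The two rings with a hetero atom are not separated: a number 0.30 log units lower from compound 1 to compound 3 (within the scatter), although their ring sizes differ. No measurement at hand accounts for either step.

Open, going by these compounds, is whether a nitrogen ring such as piperidin-4-yl, or an open-chain ether such as 2-methoxyethyl, would sit with these two rings or with cyclopentyl in this assay.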